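Chalcone boronic acid series: aryl ketone variation

The source may report more compounds than this note shows. Statements on the series, on what has been measured and on what is new or still open speak of the compounds shown alone.

Measured so far:
compound 1 `O=C(/C=C/c1ccc2c(c1)B(O)OC2)c1cccs1` — 4600 nM
compound 2 `O=C(/C=C/c1ccc2c(c1)B(O)OC2)c1ccc(Cl)cc1` — 7900 nM
compound 3 `CCc1ccc(C(=O)/C=C/c2ccc3c(c2)B(O)OC3)cc1` — 9800 nM

All three share one core and differ only in the aryl group on the carbonyl carbon. In a functional assay on MDA-MB-231 cells (Homo sapiens) for cytotoxicity, read by MTT assay, with a stated time of 48 h (a lower number here means a stronger inhibitor, a higher number a weaker inhibitor), compound 1 gives the lowest number of the three; its gap to compound 2 is a 1.7-fold higher number from compound 1 to compound 2 (0.23 log units; within the scatter), and compound 3 sits furthest from it.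

The next compound, compound 4 `O=C(/C=C/c1ccc2c(c1)B(O)OC2)c1ccc(O)cc1`, changes the same position: 4-hydroxyphenyl in place of thiophen-2-yl on a carbonyl carbon

Within the data shown here, two measured steps bear on this. The first, a 1.7-fold higher number from compound 1 to compound 2 (0.23 log units; within the scatter), exchanges the thiophen-2-yl for a six-membered carbon ring with a halogen; the second, a 1.2-fold higher number from compound 2 to compound 3 (0.09 log units; within the scatter), swaps that substituent for an alkyl group. Both stay within the scatter, so the aryl group on the carbonyl carbon has so far moved the number only a little, and always toward a higher value when leaving compound 1. Among the measured compounds shown here, no measured pair carries a hydroxyl group, so the hydrogen-bond donor that enters is untested.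

On this basis compound 4 is expected to land near compound 1, with at most a modest rise: a 1.4-fold higher number from compound 1 to compound 4 (0.15 log units; within the scatter). The estimate for compound 4 in this assay is 6500 nM, with a likely range from 2800 nM to 15000 nM.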

Compound 4, half-maximal inhibitory concentration: 25600 nM
Compound 4: middle estimate off by 3.9-fold (0.60 log units), on the low side, and the stated range ends below it.
By their numbers in this assay, from the lowest: compounds 1, 2 and 3 (each within the scatter of the next, the first and the last beyond it); then compound 4.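

In this assay the aryl group on the carbonyl carbon proves able to move the number well beyond the scatter: 4-hydroxyphenyl in place of thiophen-2-yl gives a 5.6-fold higher number from compound 1 to compound 4 (0.75 log units; beyond the scatter) whereas the two earlier single steps stayed within it. The change also registers when the six-membered ring stays and only its substituent is exchanged, since hydroxy in place of chloro gives a 3.2-fold higher number from compound 2 to compound 4 (0.51 log units; beyond the scatter) and hydroxy in place of ethyl gives a 2.6-fold higher number from compound 3 to compound 4 (0.42 log units; beyond the scatter) so that compound 4 stands apart as the weakest of the four, while the chloro and ethyl compounds remain within the scatter of each other. No measurement at hand accounts for this rise, and the compounds shown cannot separate the entering hydrogen-bond donor from the oxygen atom that comes with it.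

Open, from the compounds shown here alone, is whether a 4-methoxyphenyl or 4-aminophenyl group on the carbonyl carbon would follow the 4-hydroxyphenyl group or stay with the chloro and ethyl compounds. Also open, going by these compounds, is whether a furan-2-yl group would hold the number near that of compound 1, which would show if the five-membered ring carries any weight.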